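The compounds below may be only part of what the source reports. "The series", "measured", "known", "first", "only" and "open" are said of these compounds alone.

In a functional assay on M14 cells (Homo sapiens) for inhibition, read by sulforhodamine B assay, with a stated time of 48 h (a higher number here means a weaker inhibitor of growth, a lower number a stronger inhibitor of growth), compound 1 `O=C(Cc1csc2nc(-c3ccc(Br)cc3)cn12)N/N=C/c1ccccc1` gives > 100000 nM, which is a limit of the assay and not a number. Going by the values given here, compound 2 `O=C(Cc1csc2nc(-c3ccc(Br)cc3)cn12)N/N=C/c1ccccc1O` gives 7760 nM, the only true number so far. Hydroxy in place of hydrogen on an aromatic carbon goes with an at least 12-fold lower number from compound 1 to compound 2 (1.11 log units; beyond the scatter). Among the compounds with values here, this is the one measured step that bears on what follows, and it shows that the number in this assay can respond strongly to this group. The next structure is compound 3 `O=C(Cc1csc2nc(-c3ccc(Br)cc3)cn12)N/N=C/c1ccc(O)cc1`, and the change is 4-hydroxyphenyl in place of 2-hydroxyphenyl on a carbon with a double bond to nitrogen. Within the data shown here, no measured step tests where the hydroxy sits, so the size of this change is poorly constrained. Compound 3 still carries a hydroxy, so a result in the region of compound 2 at 7760 nM is expected. The expected change is a 1.4-fold higher number from compound 2 to compound 3 (0.15 log units; within the scatter), a small move toward a higher number and no clear shift beyond the scatter. The estimate for compound 3 is 11000 nM, with an expected range from 3000 nM to 50000 nM.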

Compound 3, concentration for total growth inhibition: 23400 nM
Estimate against measurement, compound 3: 2.1-fold (0.33 log units) below, within the range that was stated.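

In this assay, 4-hydroxyphenyl in place of 2-hydroxyphenyl, on the carbon with a double bond to nitrogen, gives a 3.0-fold higher number from compound 2 to compound 3 (0.48 log units; beyond the scatter). The two compounds have the same atoms, joined differently, so the number responds not only to whether a hydroxy is present but also to where it sits on the ring, and 2-hydroxyphenyl gives the lower of the two numbers. With the hydroxy in the 4-hydroxyphenyl group, the comparison with the unsubstituted phenyl ring still points the same way as before, with an at least 4.2-fold lower number from compound 1 to compound 3 (0.63 log units; beyond the scatter), but this size is only a bound, since compound 1 stands at a limit of the assay: the limit of > 100000 nM in this assay, at which 1 of the 3 values shown sits.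

The compounds shown leave open whether the hydroxy itself is needed, which a methoxy or an amine in the same two places on the ring would help to test. They also leave open whether 2-hydroxyphenyl keeps its lead over 4-hydroxyphenyl when a chlorine replaces the bromine on the shared core.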